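This account rests on a few compounds, and the source may have more. Where it says the series, first, only, none or still open, it means among the compounds named here.

Compound 2 `N#Cc1cccc(-n2nnc(-c3cc[nH]n3)n2)c1` sits at a limit in an assay for binding affinity to metabotropic glutamate receptor 5 (Rattus norvegicus); on this read-out higher numbers stand for weaker inhibition and lower numbers for stronger inhibition: in this assay compound 2 gives > 2000 nM, which is a limit of the assay rather than a number. Compound 1 `N#Cc1cccc(-n2nnc(-c3cscn3)n2)c1` carries a 1,3-thiazol-4-yl group on the same aromatic carbon, and in this assay compound 1 gives 157 nM. Within the data shown here, the one measured step, an at least 12-fold higher number from compound 1 to compound 2 (1.10 log units; beyond the scatter), ends at that limit (the limit of > 2000 nM in this assay, at which 1 of the 2 values shown sits). Compound 3 `N#Cc1cccc(-n2nnc(-c3c[nH]cn3)n2)c1` differs from compound 2 by 1H-imidazol-4-yl in place of 1H-pyrazol-3-yl on an aromatic carbon. Among the measured compounds shown here, no measured step exchanges a 1H-pyrazol-3-yl for a 1H-imidazol-4-yl, and the single step that bears on this pair only shows how large a change among such small azoles on this carbon can be. Compound 3 is therefore expected to remain near the limit, the step of a number no higher from compound 2 to compound 3 (the limit leaves the size open) being an estimate without a firm direction. The estimate for compound 3 in this assay is 2000 nM, with a range from 400 nM to 10000 nM.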

Compound 3, inhibition constant: > 2000 nM
Compound 3: a limit, no number; the forecaster's own chance of this, stated with the estimate: 55%; the middle value lies on the limit itself.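

In this assay, the 1H-imidazol-4-yl group on this aromatic carbon gives an at least 12-fold higher number from compound 1 to compound 3 (1.10 log units; beyond the scatter), so the large change seen with 1H-pyrazol-3-yl is no longer tied to that single group. Compound 3 stands at a limit of the assay and not at a number, and the step between compound 2 and compound 3 cannot be read, since both end at the same limit: the limit of > 2000 nM in this assay, at which 2 of the 3 values shown sit.

Going by these compounds, the two arrangements of the same ring atoms therefore cannot be told apart in this assay, and how far either compound lies beyond the limit stays unknown. Also open, on these data alone, is whether a 1,3-oxazol-4-yl or a phenyl group on this carbon would give a measurable number, as the 1,3-thiazol-4-yl group of compound 1 does.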